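Amide chain variation on the shared core: working notes

A few compounds are considered here, and "the series" means these few. Any claim that something is new, unique, unknown or untested is made for them only; others in the source may bear on it.

Measured in a functional assay on HT-29 cells (Homo sapiens) for antiproliferative activity, read by sulforhodamine B assay, with a stated time of 48 h; a higher number here means a weaker inhibitor, a lower number a stronger inhibitor:
compound 1, `CCC(=O)Nc1ccc(S(=O)(=O)Oc2ccccc2C(C)C)cc1` — 7400 nM
compound 2, `CC(C)C(=O)Nc1ccc(S(=O)(=O)Oc2ccccc2C(C)C)cc1` — 14000 nM
compound 3, `CC(C)C(=O)Nc1ccc(S(=O)(=O)Oc2ccccc2I)cc1` — 13000 nM

Compound 2 is the reference for the next step. Its neighbours in the set are compound 1 and compound 3, and neither step separates from it: a 1.9-fold higher number from compound 1 to compound 2 (0.28 log units; within the scatter), a 1.1-fold lower number from compound 2 to compound 3 (0.03 log units; within the scatter). The three numbers therefore sit together, and compound 2 cannot be set apart from either of the others on the data shown.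

The next compound is compound 4, `CC(C)c1ccccc1OS(=O)(=O)c1ccc(NC(=O)CCCCl)cc1`. It differs from compound 2 in one place: 3-chloropropyl in place of isopropyl on a carbonyl carbon. The amide substituent is thus lengthened and carries a chlorine at the far end, while the rest of the molecule, including the isopropyl on the aromatic carbon of the ester side, is kept.

For the measured compounds named here, the only step that touches the same amide carbonyl substituent is the one from compound 1 to compound 2, methyl added on the chain carbon bound to the carbonyl, and it stayed within the scatter. The change from isopropyl to iodo on the ester side, from compound 2 to compound 3, also stayed within the scatter. Nothing in the set suggests that further variation of the acyl chain moves this assay beyond the scatter, so no step beyond the scatter is expected from compound 2 to compound 4; the expected step is a 1.2-fold lower number from compound 2 to compound 4 (0.07 log units; within the scatter).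

For compound 4 the estimated value is 12000 nM, with an expected range from 5000 nM to 30000 nM.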

Compound 4, half-maximal inhibitory concentration: 6200 nM
Compound 4: middle estimate off by 1.9-fold (0.29 log units), on the high side; the range from low to high includes it.
By their numbers in this assay, from the lowest: compounds 4, 1, 3 and 2 (each within the scatter of the next, the first and the last beyond it).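

In this assay, for the compounds shown here, the substituent on the carbonyl carbon now gives the first step of the set beyond the scatter, though only a modest one (a 2.3-fold lower number from compound 2 to compound 4 (0.35 log units; beyond the scatter)), with 3-chloropropyl in place of isopropyl. Going by these compounds alone, the position is therefore not as flat as the earlier compounds suggested, but the separation holds only against the isopropyl amide: chloromethyl in place of hydrogen on a saturated chain carbon, two bonds along the chain from a carbonyl carbon, stays within the scatter (a 1.2-fold lower number from compound 1 to compound 4 (0.08 log units; within the scatter)), and compound 2 was itself not separated from compound 1, so the three amides form a shallow spread with only its two ends apart. No measurement in hand accounts for this step, and the size of the step alone cannot assign it to the chlorine, the chain length or the loss of the isopropyl branch.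

As far as these compounds go, a plain propyl on the carbonyl carbon would separate the contribution of the chlorine from that of the chain, and it remains open whether a longer chloroalkyl chain, or an amine or a carboxylic acid at the chain end, would move the number further. Also open, from the compounds shown here alone, is whether 3-chloropropyl gives a comparable step when iodo replaces isopropyl on the aromatic carbon, as in compound 3.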